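This account rests on a few compounds, and the source may have more. Where it says the series, first, only, none or still open, it means among the compounds named here.

Measured compounds in a functional assay on PC-3 cells (Homo sapiens) for antiproliferative activity, read by MTT assay, tested at 1 uM; a higher number here means a stronger effect of the compound at the concentration tested, a lower number a weaker effect:
compound 1, `COc1ccc(/C=N/NC(=O)c2cc(OC)c(OC)c(OC)c2)c(OC)c1`, gives 10%
compound 2, `COc1cc(C2=NN(C(C)=O)C(c3ccc(F)cc3)O2)cc(OC)c1OC`, gives 0%
compound 3, `COc1cc(C(=O)N/N=C/c2ccc(Cl)c(Cl)c2)cc(OC)c1OC`, gives 13.5%

Compound 2 holds the lowest of the three numbers. Its gap to compound 1 lies within the usual scatter, so no order can be read between these two. Its gap to compound 3 lies beyond the scatter, and compound 3 gives the larger inhibition at the tested concentration. All three numbers sit near the bottom of the scale, and none of the compounds shows a marked effect in this assay.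

Compound 4, `COc1cc(C2=NN(C(C)=O)C(c3ccc(C(F)(F)F)cc3)O2)cc(OC)c1OC`, is not yet measured. It differs from compound 2 in one place: trifluoromethyl in place of fluoro on an aromatic carbon. Within the data shown here, no step between measured compounds covers this kind of change, so the present numbers give no direction for it. Among the measured compounds shown here, the only anchor is compound 2, which gives 0% in this assay.

Compound 4 is therefore expected to remain weak in this assay, with an estimate of 5% and a range from 0% to 20%. The expected step is a number 5 percentage points higher from compound 2 to compound 4 (within the scatter), which stays within the scatter and does not amount to a real change.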

Compound 4, a percentage reported as inhibition, at one concentration (the size of the read-out at that concentration, not a potency): -11%
Compound 4: the middle estimate sits 16 percentage points above what was measured; the measured number lies below the stated range.
By their numbers in this assay, from the lowest: compound 4; then compounds 2, 1 and 3 (each within the scatter of the next, the first and the last beyond it).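

In this assay, among these compounds, the change from 4-fluorophenyl to 4-(trifluoromethyl)phenyl is the first one-place change that can be read, and it gives a number 11 percentage points lower from compound 2 to compound 4 (beyond the scatter), a modest step in the direction of less inhibition. This position on the aromatic ring is therefore not indifferent to the group it carries, and trifluoromethyl in place of fluoro brings no gain here: compound 4 reads -11%, a negative percentage that shows no inhibition at the tested concentration. Nothing measured on the two groups bears on this step, and the data offer no cause for it.

Only fluoro and trifluoromethyl are shown at this position, and both leave the read-out at the bottom of the scale, so it remains open whether a group such as an amine, a nitrile or a carboxylic acid would lift the inhibition at all. On these data alone, it is also open whether the same change would move the read-out in the same direction on the core of compound 1 or compound 3, which carry other groups on their aromatic rings.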